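Fluoro Moved to the Other Ring Position of the Shared Core

The compounds below may be only part of what the source reports. "The series", "measured", "known", "first", "only" and "open" are said of these compounds alone.

Compound 1 `CC(C(=O)N1CCN(c2ccccc2)CC1)N1C(=O)CCC1=O` carries the shared core, and in a functional assay on the whole organism (strain Swiss) with Mus musculus as the target, in the maximal electroshock model, with a stated time of 0.5 h, at a dose of 100 mg/kg by the intraperitoneal route (a lower number here means a weaker effect, a higher number a stronger effect of the compound at the dose given), compound 1 gives 0%. Compound 2 `CC(C(=O)N1CCN(c2ccc(F)cc2)CC1)N1C(=O)CCC1=O` gives 0% in this assay. Compound 3 `CCC(C(=O)N1CCN(c2ccccc2F)CC1)N1C(=O)CCC1=O` differs from compound 1 in several places. In this assay compound 3 gives 0%. Compound 1 therefore stands level with compounds 2 and 3 at the digits shown, with no ordering among the three that could be read beyond the scatter. Among the compounds with values here, the only measured step that rests on a single change is no change at the digits printed from compound 1 to compound 2 (within the scatter), and it is the same kind of change as the one now followed. Compound 4 `CC(C(=O)N1CCN(c2cccc(F)c2)CC1)N1C(=O)CCC1=O` differs from compound 1 by fluoro in place of hydrogen on an aromatic carbon; the same difference, cut one bond further out, reads phenyl to 3-fluorophenyl. Because the step of no change at the digits printed from compound 1 to compound 2 (within the scatter) lay within the scatter, and because compound 3 with its reading 0% matches the others at the digits shown, the change is expected to leave the reading where it is. The expected step is no change at the digits printed from compound 1 to compound 4 (within the scatter), nothing beyond the scatter. Compound 4 is estimated to give 0% in this assay, within a range from 0% to 10%.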

Compound 4, a percentage reported as activity, at one dose (the size of the read-out at that dose, not a potency): 0%
Compound 4: the middle estimate sits on the measured number at the digits printed, and the stated range covers the measured number.
By their numbers in this assay, from the lowest: compounds 1, 2, 3 and 4 (each within the scatter of the next).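

In this assay, fluoro in place of hydrogen at this place, on an aromatic carbon and meta to a large group, gives no change at the digits printed from compound 1 to compound 4 (within the scatter), so a second ring position now shows the same outcome as the earlier fluoro step. Within the data shown here, the new pair also allows the first direct comparison of two fluoro positions on the shared core: 3-fluorophenyl in place of 4-fluorophenyl gives no change at the digits printed from compound 2 to compound 4 (within the scatter), so the two placements cannot be told apart in this read-out at the dose given. No measurement shown offers an explanation for these readings, and no cause can be assigned to them.

From the compounds shown here alone, what remains open is whether any other group at this ring position, such as chloro, methoxy, trifluoromethyl or an amine, would move the reading away from that of compound 1. With all four compounds level at the digits printed, these results also leave open whether a carboxylic acid on the ring or a longer chain in place of the methyl on the shared core would separate any compound from the rest.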